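The compounds below may be only part of what the source reports. "The series", "measured", "known", "first", "only" and "open" are said of these compounds alone.

In an in vitro ADME assay on microsomes from liver (Homo sapiens) for pharmacokinetics, read by LC-MS, with a stated time of 10 min, tested at 1 uM (a higher number here means faster removal of the compound, a lower number slower removal), three compounds with the shared core have been measured. Compound 1 (`CN1C[C@H](C(=O)Nc2ccc(F)cc2)[C@@H](c2ccc(/C=C/C(=O)Nc3ccccc3N)cc2)C1`) gives 5 mL/min/kg, compound 2 (`CN1C[C@H](C(=O)Nc2cccc(F)c2)[C@@H](c2ccc(/C=C/C(=O)Nc3ccccc3N)cc2)C1`) gives 6 mL/min/kg and compound 3 (`CN1C[C@H](C(=O)Nc2ccc(Cl)c(Cl)c2)[C@@H](c2ccc(/C=C/C(=O)Nc3ccccc3N)cc2)C1`) gives 14 mL/min/kg, the highest of the three numbers. The unmeasured compound 4 (`CC(C)NC(=O)[C@H]1CN(C)C[C@@H]1c1ccc(/C=C/C(=O)Nc2ccccc2N)cc1`) differs from compound 3 in one place: isopropyl in place of 3,4-dichlorophenyl on an amide-type nitrogen. In words, isopropyl stands in place of 3,4-dichlorophenyl on an amide-type nitrogen.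

For the measured compounds named here, no measured compound carries a group without a ring at that nitrogen, so the evidence is indirect. The measured steps all exchange one aryl group for another at that same place. Between the two fluorine-bearing compounds there is a 1.2-fold higher number from compound 1 to compound 2 (0.08 log units; within the scatter). The 3,4-dichlorophenyl group appears in a 2.8-fold higher number from compound 1 to compound 3 (0.45 log units; beyond the scatter) and in a 2.3-fold higher number from compound 2 to compound 3 (0.37 log units; beyond the scatter). With that group gone, compound 4 is expected to lie closer to compound 1 at 5 mL/min/kg and compound 2 at 6 mL/min/kg than to compound 3 at 14 mL/min/kg. The expected change is a 2.3-fold lower number from compound 3 to compound 4 (0.37 log units; beyond the scatter), a modest move towards slower removal, though an untested kind of group keeps this uncertain. For compound 4 the estimate is 6 mL/min/kg, with an expected range from 3 mL/min/kg to 13 mL/min/kg.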

Compound 4, clearance: 8 mL/min/kg
Compound 4: middle estimate off by 1.3-fold (0.12 log units), on the low side; the measured number falls inside the stated range.
By their numbers in this assay, from the lowest: compounds 1, 2, 4 and 3 (each within the scatter of the next, the first and the last beyond it).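

With isopropyl on the amide-type nitrogen, this assay now has a group without a ring at this position, and the change from the aryl groups does not separate it from any of them: the exchange for 3,4-dichlorophenyl gives a 1.8-fold lower number from compound 3 to compound 4 (0.24 log units; within the scatter), the exchange for 3-fluorophenyl gives a 1.3-fold higher number from compound 2 to compound 4 (0.12 log units; within the scatter), and the exchange for 4-fluorophenyl gives a 1.6-fold higher number from compound 1 to compound 4 (0.20 log units; within the scatter). The earlier compounds shown here offered only aryl groups here, and among them the 3,4-dichlorophenyl group stood apart, with a 2.8-fold higher number from compound 1 to compound 3 (0.45 log units; beyond the scatter) and a 2.3-fold higher number from compound 2 to compound 3 (0.37 log units; beyond the scatter); compound 4 shows that an aromatic ring at this nitrogen is not required for a number in this range, and it sits within the scatter of both ends of that aryl series. Nothing shown here gives a reason for these numbers.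

The compounds shown leave open whether a longer chain such as n-butyl, a chain ending in an amine, or one ending in a carboxylic acid at this nitrogen would stay in the same range. They also leave open whether a phenyl group carrying a single chlorine would follow the fluorine-bearing compounds or compound 3.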